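The compounds below may be only part of what the source reports. "The series", "measured", "known", "first", "only" and "open" are said of these compounds alone.

In a functional assay on cells (Panel ovarian (Carcinoma cell lines), Homo sapiens) for inhibition (a lower number here means a stronger inhibitor of growth, a higher number a weaker inhibitor of growth), compound 1 (`Cc1ccnc2nc(-c3cccc(Cl)c3)cc(O)c12`) gives 27500 nM and compound 2 (`Cc1ccc2c(O)cc(-c3cccc(Cl)c3)nc2n1`) gives 10500 nM on the same scale. Compound 3 (`Cc1cc(C)c2c(O)cc(-c3cccc(F)c3)nc2n1`) gives 5500 nM as its number, within the scatter of compound 2 and beyond the scatter below compound 1. Compound 4 (`Cc1cc(C)c2c(O)cc(-c3cccc(Cl)c3)nc2n1`) differs from compound 3 by chloro in place of fluoro on an aromatic carbon in the form of chloro in place of fluoro on an aromatic carbon. Among the measured compounds shown here, no measured pair shows this exchange alone, so the expectation is weakly founded. In this assay no change beyond the scatter is expected, and neither direction is favoured. The expected step is a 1.2-fold higher number from compound 3 to compound 4 (0.07 log units; within the scatter) and stays within the scatter. For compound 4 the estimated value is 6500 nM within an expected range from 2500 nM to 15000 nM in this series.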

Compound 4, concentration for total growth inhibition: 30200 nM
Estimate against measurement, compound 4: 4.6-fold (0.67 log units) below, outside the stated range (above it).
By their numbers in this assay, from the lowest: compounds 3 and 2 (each within the scatter of the next); then compounds 1 and 4 (each within the scatter of the next).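

In this assay the exchange of chloro in place of fluoro on an aromatic carbon, meta to a large group, can now be read alone, and it is not neutral (a 5.5-fold higher number from compound 3 to compound 4 (0.74 log units; beyond the scatter)). Methyl in place of hydrogen on an aromatic carbon has no single size in this series (a 2.9-fold higher number from compound 2 to compound 4 (0.46 log units; beyond the scatter); a 1.1-fold higher number from compound 1 to compound 4 (0.04 log units; within the scatter)). No measurement here gives a reason for either result.

Still open, on these data alone, is how bromo, methoxy or an amine on this aromatic carbon would compare with compound 3 and compound 4.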